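A few compounds are considered here, and "the series" means these few. Any claim that something is new, unique, unknown or untested is made for them only; others in the source may bear on it.

Compound 3 `O=C(N/N=C/c1cc(I)cc(I)c1O)c1ccc(F)cc1` carries a 4-fluorophenyl group on the shared core. In a functional assay on HepG2 cells (Homo sapiens) for cytotoxicity, with a stated time of 24 h (a lower number here means a stronger inhibitor, a higher number a weaker inhibitor), compound 3 gives 12100 nM, the lowest of the two numbers recorded; compound 2 `O=C(N/N=C/c1cc(I)cc(I)c1O)c1ccc(O)cc1` gives 19200 nM, and the step of a 1.6-fold lower number from compound 2 to compound 3 (0.20 log units; within the scatter) lies within the scatter. Compound 1 `O=C(N/N=C/c1cc(I)cc(I)c1O)c1ccccc1` reaches only (the limit of > 50000 nM in this assay, at which 1 of the 3 values shown sits), so its entry > 50000 nM is a limit rather than a number. Compound 4 `O=C(N/N=C/c1cc(I)cc(I)c1O)c1ccc(I)cc1` differs from compound 3 by iodo in place of fluoro on an aromatic carbon. Among the measured compounds shown here, no measured pair swaps one halogen for another; the nearest guides are an at least 4.1-fold lower number from compound 1 to compound 3 (0.61 log units; beyond the scatter), where fluoro replaced hydrogen, and a 1.6-fold lower number from compound 2 to compound 3 (0.20 log units; within the scatter), where fluoro replaced hydroxy with little effect. The step of a 1.3-fold lower number from compound 3 to compound 4 (0.13 log units; within the scatter) is therefore expected to be small. For compound 4 the estimated value is 9000 nM, with a range from 3000 nM to 30000 nM.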

Compound 4, half-maximal inhibitory concentration: 31800 nM
Beside the measured number, compound 4's estimate is 3.5-fold (0.55 log units) below it; the whole stated range lies below it.
By their numbers in this assay, from the lowest: compounds 3, 2 and 4 (each within the scatter of the next, the first and the last beyond it). At a limit, above all of these: compound 1.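

Among the compounds shown here, changing one halogen for another at this position is not neutral: with a 2.6-fold higher number from compound 3 to compound 4 (0.42 log units; beyond the scatter), fluoro and iodo can be told apart, which no earlier pair could show. Iodo and hydroxy cannot be separated, with a 1.7-fold higher number from compound 2 to compound 4 (0.22 log units; within the scatter) as the step between them. Only a floor can be read from an at least 1.5-fold lower number from compound 1 to compound 4 (0.19 log units; that floor lies within the scatter), since the entry for compound 1 is a limit: the limit of > 50000 nM in this assay, at which 1 of the 4 values shown sits.

The compounds shown leave open where chloro or bromo would fall between fluoro and iodo. On these data alone, how an amine or a carboxylic acid would read at this position also remains open.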